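Cytotoxicity Limits Across Three Amides and an Untested Fourth

The source may report more compounds than this note shows. Statements on the series, on what has been measured and on what is new or still open speak of the compounds shown alone.

Compound 1 `Cn1c(-c2ccccc2)cnc1NC(=O)c1ncc[nH]1`: > 100000 nM
Compound 2 `Cn1c(-c2cccc(Br)c2)cnc1NC(=O)c1ccc(F)cc1`: > 50000 nM
Compound 3 `COc1ccc(-c2cnc(NC(=O)C3CCOCC3)n2C)cc1`: > 100000 nM

All three were examined in a toxicity assay on THP-1 cells (Homo sapiens) for inhibition; a higher number here means that more compound is tolerated, a lower number that less compound is tolerated. For compound 3 the result is only a limit of the assay, not a number. Compound 1 also rests at a limit, (the limit of > 100000 nM in this assay, at which 2 of the 3 values shown sit). Compound 2 rests at a different limit, (the limit of > 50000 nM in this assay, at which 1 of the 3 values shown sits). Compound 3 therefore cannot be ranked against the other two; every value shown is a limit.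

Compound 4 `COc1ccc(-c2cnc(NC(=O)c3ccc(Cl)cc3)n2C)cc1` has not been measured. It differs from compound 3 by 4-chlorophenyl in place of oxan-4-yl on a carbonyl carbon. Within the data shown here, no step between two measured compounds is available, so the data give no size for this change. Compound 4 is expected to show a step of a number no higher from compound 3 to compound 4 (the limit leaves the size open), none beyond the scatter. Compound 4 is estimated at 100000 nM, with a range from 30000 nM to 300000 nM, most likely reported again only as a limit.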

Compound 4, half-maximal cytotoxic concentration: > 100000 nM
Compound 4 ended at the assay's limit; the forecaster's own chance of this, stated with the estimate: 80%; the middle value sits exactly at the limit.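

Compound 3 and compound 4 both rest at a limit of this assay, so no step can be read between them. The compounds shown leave open whether 4-chlorophenyl in place of oxan-4-yl changes cytotoxicity at all.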